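Methoxy for methyl on a thiourea-linked aryl ring

A few compounds are considered here, and "the series" means these few. Any claim that something is new, unique, unknown or untested is made for them only; others in the source may bear on it.

Measured compounds:
Compound 1, `NC(=O)c1c(NC(=O)c2ccccc2C(F)(F)F)sc2c1CCN(C(=S)Nc1ccccc1Cl)C2`, in a functional assay on HL-60 cells (Homo sapiens) for antiproliferative activity, with a stated time of 24 h (a lower number here means a stronger inhibitor, a higher number a weaker inhibitor), gives 17600 nM.
Compound 2, `Cc1ccccc1NC(=S)N1CCc2c(sc(NC(=O)c3ccccc3C(F)(F)F)c2C(N)=O)C1`, in this assay gives 25100 nM.

Compound 2 stands at the weaker-looking end of these two numbers, but the step of a 1.4-fold higher number from compound 1 to compound 2 (0.15 log units; within the scatter) shows that compound 1 and compound 2 are not separated beyond the usual scatter of this assay. Compound 3, `COc1ccccc1NC(=S)N1CCc2c(sc(NC(=O)c3ccccc3C(F)(F)F)c2C(N)=O)C1`, differs from compound 2 in one place: methoxy in place of methyl on an aromatic carbon. Among the compounds with values here, the only measured step at this position, a 1.4-fold higher number from compound 1 to compound 2 (0.15 log units; within the scatter), exchanged one small substituent for another on the same aromatic carbon and left the number essentially unchanged. Nothing measured here points to a larger effect of a methoxy group, so the step of a 1.0-fold lower number from compound 2 to compound 3 (0.00 log units; within the scatter) is expected to stay within the scatter. Compound 3 is therefore estimated at 25000 nM in this assay, with a range from 10000 nM to 63000 nM.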

Compound 3, half-maximal inhibitory concentration: > 50000 nM
Compound 3: a limit, no number; the forecaster's own chance of this, stated with the estimate: 15%; middle value at least 2.0-fold (0.30 log units) away from the limit.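

Compound 3 is recorded only as a limit and not as a number: the limit of > 50000 nM in this assay, at which 1 of the 3 values shown sits.

Against the methyl group, the step of an at least 1.9-fold higher number from compound 2 to compound 3 (0.29 log units; that floor lies within the scatter) has a floor that does not by itself clear the scatter, so this change cannot be sized from that pair alone. Against the chloro group, the step of an at least 2.8-fold higher number from compound 1 to compound 3 (0.45 log units; beyond the scatter) does clear it, so methoxy is the first group shown on this aromatic carbon, ortho to a large group, to be separated from another beyond the scatter, which the step between chloro and methyl did not show.

The compounds shown leave open how an amine, a hydroxyl group or a longer chain such as ethoxy would read at this position. They also leave open whether methoxy would give the same result on another carbon of this ring.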